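Swapping an aryl amide for a propyl chain: compound 3

This account rests on a few compounds, and the source may have more. Where it says the series, first, only, none or still open, it means among the compounds named here.

Measured so far:
Compound 1, `Cc1cccc(Cn2c(CN3CCN(C(=O)c4ccc(C(F)(F)F)cc4)CC3)nc3ccccc32)c1`, gives 22.9% in an assay on isolated protein for inhibition of aldehyde dehydrogenase 1A1 (Homo sapiens), read by spectrophotometry, tested at 10 uM; a higher number here means more inhibition at the concentration tested (going by the name of the read-out), a lower number less inhibition.
Compound 2, `CC(C)CCn1c(OC2CCN(C(=O)c3ccco3)CC2)nc2ccccc21`, gives 30.8% in this assay.

Both numbers are low, and compound 1 and compound 2 lie within the usual scatter of each other, so neither stands apart in this assay.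

Compound 3, `CCCC(=O)N1CCN(Cc2nc3ccccc3n2Cc2cccc(C)c2)CC1`, differs from compound 1 in one place: propyl in place of 4-(trifluoromethyl)phenyl on a carbonyl carbon. Within the data shown here, no measured pair shows a change of this kind, so there is no step to lean on. Compound 3 is expected to give 15%, with a range from 0% to 35%. The step of a number 7.9 percentage points lower from compound 1 to compound 3 (within the scatter) is expected to be small, downward if anything, and not beyond the scatter.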

Compound 3, a percentage reported as inhibition, at one concentration (the size of the read-out at that concentration, not a potency): 79.1%
Estimate against measurement, compound 3: 64.1 percentage points below; measured number above the stated range.
By their numbers in this assay, from the lowest: compounds 1 and 2 (each within the scatter of the next); then compound 3.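

Putting propyl in place of 4-(trifluoromethyl)phenyl on the carbonyl carbon gives a number 56.2 percentage points higher from compound 1 to compound 3 (beyond the scatter) in this assay and the rest of the molecule stays the same. This one position can therefore carry a large change, and compound 3 shows that an aromatic ring is not needed there for high inhibition. No measurement here explains the jump.

From the compounds shown here alone, whether the gain belongs to propyl itself stays open. Methyl, a longer chain such as butyl, or plain phenyl on the same carbonyl would help separate chain length from loss of the ring.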